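The source may report more compounds than this note shows. Statements on the series, on what has been measured and on what is new or still open speak of the compounds shown alone.

Compound 1 `Cc1ccc(NC(=O)Nc2cccc(CNc3nccnc3Cl)c2)c(C)c1`: 10100 nM
Compound 2 `O=C(Nc1ccc(C(F)(F)F)cc1)Nc1cccc(CNc2nccnc2Cl)c1`: 6910 nM

In a functional assay on MGC-803 cells (Homo sapiens) for antiproliferative activity, read by MTT assay, with a stated time of 48 h (on this read-out higher numbers stand for weaker inhibition and lower numbers for stronger inhibition), compound 2 gives 6910 nM, and that number lies within the scatter of the value for compound 1. Compound 3 `Cc1ccc(NC(=O)Nc2cccc(CNc3nccnc3Cl)c2)cc1` is still unmeasured. It differs from compound 2 by methyl in place of trifluoromethyl on an aromatic carbon, para to a large group. For the measured compounds named here, no measured pair isolates this change. Compound 1, which also bears methyl, gives 10100 nM, so no step beyond the scatter is expected in this assay. The expected change is a 1.3-fold higher number from compound 2 to compound 3 (0.11 log units; within the scatter). For compound 3 the estimated value is 9000 nM, with an expected range from 4000 nM to 20000 nM.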

Compound 3, half-maximal inhibitory concentration: 11900 nM
Compound 3: middle estimate off by 1.3-fold (0.12 log units), on the low side, and the stated range covers the measured number.
By their numbers in this assay, from the lowest: compounds 2, 1 and 3 (each within the scatter of the next).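

In this assay, the exchange of trifluoromethyl for methyl on this aromatic carbon, para to a large group, gives a 1.7-fold higher number from compound 2 to compound 3 (0.24 log units; within the scatter), so this change does not separate the two compounds. Hydrogen in place of methyl on an aromatic carbon gives a 1.2-fold higher number from compound 1 to compound 3 (0.07 log units; within the scatter) and likewise leaves the values within the scatter of each other. Nothing available explains why these values lie so close. Going by these compounds, whether an amine, a carboxylic acid or a longer chain on this aromatic carbon would give a step beyond the scatter remains open.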